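The source may hold more compounds than are shown below. What is called first, only, known or untested is meant among the compounds shown, and "the series" means these compounds.

Measured so far, in a functional assay on A549 cells (Homo sapiens) for cytotoxicity, read by MTT assay, with a stated time of 72 h; on this read-out lower numbers stand for stronger inhibition and higher numbers for weaker inhibition:
compound 1, `O=C(N/N=C/c1ccc(F)cc1Cl)Nc1cc2c(Nc3ccc(F)c(Cl)c3)ncnc2cc1O[C@H]1CCOC1`, gives 27200 nM
compound 2, `O=C(N/N=C/c1cccc(Cl)c1Cl)Nc1cc2c(Nc3ccc(F)c(Cl)c3)ncnc2cc1O[C@H]1CCOC1`, gives 25000 nM
compound 3, `COc1cc2ncnc(Nc3ccc(F)c(Cl)c3)c2cc1NC(=O)N/N=C/c1ccc(F)cc1Cl`, gives 28200 nM

All three numbers lie within the scatter of one another, so no order among them can be read. From compound 1 to compound 2 the change is 2,3-dichlorophenyl in place of 2-chloro-4-fluorophenyl on a carbon with a double bond to nitrogen, and the step it made is a 1.1-fold lower number from compound 1 to compound 2 (0.04 log units; within the scatter). Compound 4, `COc1cc2ncnc(Nc3ccc(F)c(Cl)c3)c2cc1NC(=O)N/N=C/c1cccc(Cl)c1Cl`, is not yet measured. It differs from compound 3 by 2,3-dichlorophenyl in place of 2-chloro-4-fluorophenyl on a carbon with a double bond to nitrogen. Within the data shown here, this is the same change as the one from compound 1 to compound 2: the group that leaves, the group that enters and the place where it sits are described in the same words. The two changes are made on different cores, and how these cores differ is given by methyl in place of oxolan-3-yl on an oxygen on an aromatic ring; that core difference itself gave a step of a 1.0-fold higher number from compound 1 to compound 3 (0.02 log units; within the scatter), which is within the scatter.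

With the same change made once already, and the core difference not moving the number beyond the scatter, the expectation for compound 4 rests on compound 2 and on a 1.1-fold lower number from compound 1 to compound 2 (0.04 log units; within the scatter). The step is expected to be a 1.1-fold lower number from compound 3 to compound 4 (0.04 log units; within the scatter), because the earlier instance of the change gave a 1.1-fold lower number from compound 1 to compound 2 (0.04 log units; within the scatter). Compound 4 is therefore estimated at 25500 nM, with a likely range from 13000 nM to 50000 nM. A number outside this range would mean the change behaves differently on the core of compound 3 than on the core of compound 1.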

Compound 4, half-maximal inhibitory concentration: 35300 nM
Estimate against measurement, compound 4: 1.4-fold (0.14 log units) below; measured number inside the range.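

In this assay, 2,3-dichlorophenyl in place of 2-chloro-4-fluorophenyl gives a 1.3-fold higher number from compound 3 to compound 4 (0.10 log units; within the scatter), and this agrees with the earlier instance of the change on the core of compound 1: the same change on two cores in this assay, a 1.1-fold lower number (0.04 log units; within the scatter) from compound 1 to compound 2 and a 1.3-fold higher number (0.10 log units; within the scatter) from compound 3 to compound 4, 1.4-fold (0.13 log units) apart, within the scatter of two such steps

Read the other way round the same square, methyl in place of oxolan-3-yl on an oxygen on an aromatic ring gives a 1.4-fold higher number from compound 2 to compound 4 (0.15 log units; within the scatter), and this agrees with the first instance of that change: the same change on two cores in this assay, a 1.0-fold higher number (0.02 log units; within the scatter) from compound 1 to compound 3 and a 1.4-fold higher number (0.15 log units; within the scatter) from compound 2 to compound 4, 1.4-fold (0.13 log units) apart, within the scatter of two such steps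

Across these four compounds, then, neither change moves the number beyond the scatter on either core, and the two places show no sign of depending on each other; steps this small do not show, however, that a change with a step beyond the scatter would carry from one core to the other in the same way.

As far as these compounds go, the groups on the carbon with a double bond to nitrogen are both chlorine-bearing phenyl rings, so it stays open whether a phenyl ring carrying an amine, a nitrile or a carboxylic acid would give a step beyond the scatter, and whether such a step would carry between the two cores. On the oxygen only methyl and oxolan-3-yl appear, which leaves open what a longer chain ending in an amine would do there.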